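The source may hold more compounds than are shown below. What is called first, only, known or untested is meant among the compounds shown, and "the series" means these compounds.

Notes on the series. Within the data shown here, compound 1 `O=S(=O)(Nc1ccc2oc(-c3ccccc3)nc2c1)c1cccc(C(F)(F)F)c1` is one of three compounds measured in an assay on isolated protein for inhibition of malate dehydrogenase, mitochondrial (Sus scrofa), with stated times of 45 min and 30 min; a higher number here means a weaker inhibitor, a lower number a stronger inhibitor. For compound 1 the assay returned only a limit, > 63000 nM. Compound 2 `O=S(=O)(Nc1ccc(-c2nc3ccccc3o2)cc1)c1ccccc1Cl` likewise gave only a limit, > 63000 nM. Compound 3 `O=S(=O)(Nc1ccc(-c2nc3ccccc3o2)cc1)c1ccc(O)cc1` also stopped at a limit, > 63000 nM. Among the measured compounds shown here, the one step between measured compounds that differ in a single place, 4-hydroxyphenyl in place of 2-chlorophenyl on a sulfonyl sulfur, is a step that the two limits leave unreadable from compound 2 to compound 3. All three values sit at the limit of > 63000 nM in this assay, at which 3 of the 3 values shown sit, so compound 1 stands exactly where the other two stand, at the limit, and no order among them can be read.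

Compound 4 `Cc1cccc(S(=O)(=O)Nc2ccc3oc(-c4ccccc4)nc3c2)c1` differs from compound 1 by methyl in place of trifluoromethyl on an aromatic carbon. For the measured compounds named here, no measured step bears on this change, the only step available being unreadable, and nothing shows a movement off the limit. The expectation is therefore no step beyond the scatter that could be read, with the estimated step in this assay being a step that the limit leaves unreadable from compound 1 to compound 4. Compound 4 is expected to sit at 150000 nM, with a range from 50000 nM to 500000 nM, and most likely again to be reported only as a limit.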

Compound 4, half-maximal inhibitory concentration: > 63000 nM
Compound 4: no number, only a limit; the forecaster's own chance of this, stated with the estimate: 85%; the middle value does not contradict the limit.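

Compound 4 returned only a limit, > 63000 nM. Compound 1 and compound 4 therefore yield no readable step, and all values shown remain limits: the limit of > 63000 nM in this assay, at which 4 of the 4 values shown sit.

The compounds shown leave open whether methyl and trifluoromethyl differ at all in their effect on inhibition, and what structural change would give a measurable value.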